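Notes on the carbonyl substituent in a piperidine ether series

The source may hold more compounds than are shown below. What is called first, only, known or untested is meant among the compounds shown, and "the series" means these compounds.

Measured so far:
compound 1 `Cc1nc(S(C)(=O)=O)ccc1Oc1ncnc(OC2CCN(C(=O)SC3(C)CC3)CC2)c1F` gives 166 nM in a functional assay on isolated protein for inhibition of Glucose-dependent insulinotropic receptor (Rattus norvegicus), read by HTRF and cAMP accumulation; a lower number here means that less compound is needed, a higher number that more compound is needed for the effect
compound 2 `Cc1nc(S(C)(=O)=O)ccc1Oc1ncnc(OC2CCN(C(=O)C3CCCC3)CC2)c1F` gives 407 nM in this assay

Compound 2 holds the highest of the two numbers measured in this assay; its nearest neighbour is compound 1, and the step of a 2.5-fold higher number from compound 1 to compound 2 (0.39 log units; beyond the scatter) is a modest one, beyond the scatter. That step is the only measured one, and it concerns an exchange of two saturated groups on the carbonyl carbon.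

Compound 3 `CCc1cnc(C(=O)N2CCC(Oc3ncnc(Oc4ccc(S(C)(=O)=O)nc4C)c3F)CC2)nc1` is not yet measured. It differs from compound 2 by 5-ethylpyrimidin-2-yl in place of cyclopentyl on a carbonyl carbon whose other neighbours are an amide-type nitrogen in a ring. Within the data shown here, no measured step covers an aromatic group on that carbonyl, so the step of a 2.5-fold higher number from compound 1 to compound 2 (0.39 log units; beyond the scatter) bears on it only in showing that this position is sensitive to modest shifts in this assay. For compound 3 a modest step is therefore expected, a 1.6-fold lower number from compound 2 to compound 3 (0.21 log units; within the scatter), but its direction is uncertain. Compound 3 is estimated at 250 nM in this assay, within a range of 80 nM to 900 nM.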

Compound 3, half-maximal effective concentration: 40.8 nM
Compound 3: middle estimate off by 6.1-fold (0.79 log units), on the high side; measured number below the stated range.
By their numbers in this assay, from the lowest: compound 3; then compound 1; then compound 2.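

Placing an aromatic ring on this carbonyl carbon, whose other neighbour is the amide-type ring nitrogen, gives a 10-fold lower number from compound 2 to compound 3 (1.00 log units; beyond the scatter) in this assay; the earlier pair covered only saturated groups and could not show that such a ring is accepted here, let alone that it lowers the number. Against the sulfur-linked methylcyclopropyl group, the same position shows a 4.1-fold lower number from compound 1 to compound 3 (0.61 log units; beyond the scatter), so compound 3 has the lowest of the three numbers, with both of its steps beyond the scatter. No measurement shown here accounts for this shift, and the reason for it remains unknown.

The change from cyclopentyl to 5-ethylpyrimidin-2-yl alters the ring size, aromaticity, ring nitrogens and ethyl substituent together, so the share of each in the step cannot be separated from these compounds. A plain phenyl, pyrimidin-2-yl without the ethyl, and 5-propylpyrimidin-2-yl, a group with a longer chain, would each be needed to show which of these features carries the lower number in this assay.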